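Removing a methyl from a methoxy group: the next step

The source may hold more compounds than are shown below. What is called first, only, known or untested is meant among the compounds shown, and "the series" means these compounds.

The measured compounds and their values in a functional assay on HCT-116 cells (Homo sapiens) for inhibition, read by MTT assay, with a stated time of 48 h; on this read-out higher numbers stand for weaker inhibition and lower numbers for stronger inhibition:
- compound 1, `C/C=C/C(=O)N(Cc1ccc(OC)c(OC)c1)c1cc(OC)c(OC)c(OC)c1`, 32800 nM
- compound 2, `COc1ccc(CNc2cc(OC)c(OC)c(OC)c2)cc1Br`, 48100 nM
- compound 3, `COc1ccc(CNc2cc(OC)c(OC)c(OC)c2)cc1F`, 32200 nM

All three compounds share the same core and sit close together. Compound 1 gives the second highest of the three numbers; its nearest neighbour is compound 3 and its furthest is compound 2, and both gaps are within the scatter, so none of the three can be called stronger or weaker than another. Among the measured compounds shown here, the only step between compounds differing in one place is a 1.5-fold lower number from compound 2 to compound 3 (0.17 log units; within the scatter), and that change lies on a different part of the molecule from the one now at issue.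

Compound 4, `C/C=C/C(=O)N(Cc1ccc(OC)c(O)c1)c1cc(OC)c(OC)c(OC)c1`, differs from compound 1 by hydrogen in place of methyl on an oxygen on an aromatic ring. For the measured compounds named here, no measured step speaks to this kind of change, so there is no basis to expect a move beyond the scatter in this assay . Compound 4 is therefore estimated at 35000 nM, with a range from 12000 nM to 100000 nM, which amounts to an expected step of a 1.1-fold higher number from compound 1 to compound 4 (0.03 log units; within the scatter).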

Compound 4, half-maximal inhibitory concentration: 55 nM
Beside the measured number, compound 4's estimate is 640-fold (2.80 log units) above it; measured number below the stated range.
By their numbers in this assay, from the lowest: compound 4; then compounds 3, 1 and 2 (each within the scatter of the next).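

In this assay, the single change of methoxy to hydroxy gives a 600-fold lower number from compound 1 to compound 4 (2.78 log units; beyond the scatter), the only step among these compounds that lies beyond the scatter. The earlier compounds shown here all sat close together and gave no sign that activity could depend so sharply on one place, yet the loss of just one methyl group is enough here. Nothing shown explains why this one change has so large an effect.

From the compounds shown here alone, it remains open whether a hydroxy is specifically needed at this place, or whether another group there, such as an amine or an ethoxy, would also give a low number. Going by these compounds, it is also open whether the same change at any of the other methoxy groups of compound 4 would act in the same way.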